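A few compounds are considered here, and "the series" means these few. Any claim that something is new, unique, unknown or untested is made for them only; others in the source may bear on it.

Three compounds have been measured:

compound 1, `COc1ccc(-c2cc(/C=C/C(=O)c3ccc(N)cc3)[nH]n2)cc1`, 88%
compound 2, `COc1ccc(C(=O)/C=C/c2cc(-c3cc(OC)c(OC)c(OC)c3)n[nH]2)cc1OC`, 74%
compound 3, `COc1ccc(-c2cc(/C=C/C(=O)c3ccc(N)cc3)[nH]n2)cc1OC`, 87%

These numbers come from a functional assay on 786-0 cells (Homo sapiens) for cytotoxicity, read by sulforhodamine B assay, with a stated time of 48 h, tested at 1 uM; a higher number here means a weaker effect of the compound at the concentration tested, a lower number a stronger effect. Compound 1 and compound 3 differ in one place, (methoxy in place of hydrogen on an aromatic carbon), and that change gave a number 1 percentage points lower from compound 1 to compound 3 (within the scatter). Compound 2 has the lowest of the three numbers; its nearest neighbour is compound 3, and its gaps to compound 3 and to compound 1 both lie beyond the scatter. The difference between the core of compound 2 and the core of compound 1 is not broken down here.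

Compound 4, `COc1cc(C(=O)/C=C/c2cc(-c3cc(OC)c(OC)c(OC)c3)n[nH]2)cc(OC)c1OC`, has not yet been measured in this assay. It differs from compound 2 by methoxy in place of hydrogen on an aromatic carbon. This is the same kind of change as from compound 1 to compound 3, though the surroundings are not identical: in compound 4 the entering group is also meta to a methoxy group. Among the measured compounds shown here, the earlier case of this change gave a number 1 percentage points lower from compound 1 to compound 3 (within the scatter), which is the only guide available. A similarly small step is expected for compound 4, a number 3 percentage points lower from compound 2 to compound 4 (within the scatter). Compound 4 is therefore estimated at 71%, with an expected range from 55% to 86%.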

Compound 4, a percentage reported as activity, at one concentration (the size of the read-out at that concentration, not a potency): 80%
Compound 4: middle estimate off by 9 percentage points, on the low side, and the stated range covers the measured number.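

In this assay, methoxy in place of hydrogen on an aromatic carbon gave a number 6 percentage points higher from compound 2 to compound 4 (within the scatter), so this step cannot be told apart from no change at all. Set beside the earlier case, the two steps do not differ: the same change on two cores in this assay, a number 1 percentage points lower (within the scatter) from compound 1 to compound 3 and a number 6 percentage points higher (within the scatter) from compound 2 to compound 4, 7 percentage points apart, within the scatter of two such steps On these two cores, then, the change travels in the sense that neither step leaves the scatter, but this rests on only two pairs at one concentration, and it does not show that the change is without effect on every core or that it would behave the same way at other concentrations.

The compounds shown leave open whether a group other than methoxy at the same place on the ring, such as a hydroxyl, a fluorine or a longer chain like ethoxy, would move the read-out beyond the scatter. They also leave open whether the methoxy change would stay this small on a third core.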